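This account rests on a few compounds, and the source may have more. Where it says the series, first, only, none or still open, it means among the compounds named here.

- Compound 1 `O=C(/C=C/c1cn(S(=O)(=O)c2ccc([N+](=O)[O-])cc2)c2ccccc12)c1ccncc1`: 18300 nM
- Compound 2 `COc1ccc(S(=O)(=O)n2cc(/C=C/C(=O)c3ccncc3)c3ccccc32)cc1`: 26000 nM

In a functional assay on HepG2 cells (Homo sapiens) for antiproliferative activity, read by MTT assay, with a stated time of 48 h (on this read-out lower numbers stand for stronger inhibition and higher numbers for weaker inhibition), compound 2 gives 26000 nM, a value that cannot be told apart from that of compound 1 at 18300 nM. Compound 3 `O=C(/C=C/c1cn(S(=O)(=O)c2cccc3ccccc23)c2ccccc12)c1ccncc1` differs from compound 2 in one place: naphthalen-1-yl in place of 4-methoxyphenyl on a sulfonyl sulfur. Put simply, naphthalen-1-yl stands in place of 4-methoxyphenyl on a sulfonyl sulfur. Going by the values given here, only one measured step bears on this change. Methoxy in place of nitro on an aromatic carbon gave a 1.4-fold higher number from compound 1 to compound 2 (0.15 log units; within the scatter), which is within the scatter. Among the compounds with values here, no compound measured so far carries naphthalen-1-yl, so the data offer no direction, and no step beyond the scatter is expected in this assay. The expected change is a 1.2-fold lower number from compound 2 to compound 3 (0.07 log units; within the scatter). Compound 3 is estimated at 22000 nM, with an expected range from 8000 nM to 55000 nM.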

Compound 3, half-maximal inhibitory concentration: 62900 nM
Compound 3: middle estimate off by 2.9-fold (0.46 log units), on the low side; the measured number lies above the stated range.
By their numbers in this assay, from the lowest: compounds 1 and 2 (each within the scatter of the next); then compound 3.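

In this assay, the group on the sulfonyl sulfur turns out to matter: naphthalen-1-yl in place of 4-methoxyphenyl gives a 2.4-fold higher number from compound 2 to compound 3 (0.38 log units; beyond the scatter), and in place of 4-nitrophenyl it gives a 3.4-fold higher number from compound 1 to compound 3 (0.54 log units; beyond the scatter). Going by these compounds alone, the earlier exchange of nitro for methoxy, a 1.4-fold higher number from compound 1 to compound 2 (0.15 log units; within the scatter), had left the number within the scatter, so this is the first sign that inhibition at this position can be lost, though both new steps are modest. No measurement shown here accounts for the weaker inhibition.

Within the data shown here, with only one compound carrying naphthalen-1-yl, the result cannot say whether other groups with two aromatic rings would behave the same way. As far as these compounds go, it also remains open how an amine on the phenyl ring, or a plain methyl directly on the sulfonyl sulfur, would compare.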